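Amide nitrogen aryl swaps in the paw edema series

The source may report more compounds than this note shows. Statements on the series, on what has been measured and on what is new or still open speak of the compounds shown alone.

Three compounds sharing one core have been run in a functional assay on the whole organism for inhibition, with Rattus norvegicus as the target, read by cytopathic effect and paw edema, at a dose of 100 mg/kg by the oral route; on this read-out higher numbers stand for more inhibition at the one dose given (going by the name of the read-out) and lower numbers for less inhibition. Compound 1 `CNC(=O)c1c(O)c2cccnc2n(-c2ccccc2)c1=O` gives 21%, compound 2 `O=C(Nc1ccc(Cl)cc1)c1c(O)c2cccnc2n(-c2ccccc2)c1=O` gives 2.5%, and compound 3 `O=C(Nc1cccc([N+](=O)[O-])c1)c1c(O)c2cccnc2n(-c2ccccc2)c1=O` gives 7.4%. Compound 3 is the second highest of the three numbers: its nearest neighbour is compound 2, within the scatter, and its furthest is compound 1, beyond the scatter. The two steps away from compound 1, a number 18.5 percentage points lower from compound 1 to compound 2 (beyond the scatter) and a number 13.6 percentage points lower from compound 1 to compound 3 (beyond the scatter), both show an aryl group on the amide-type nitrogen giving a lower number than methyl there. The step between the two aryl groups, a number 4.9 percentage points higher from compound 2 to compound 3 (within the scatter), lies within the scatter.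

Compound 4 `O=C(Nc1cccnc1)c1c(O)c2cccnc2n(-c2ccccc2)c1=O` differs from compound 3 only at that same position: pyridin-3-yl in place of 3-nitrophenyl on an amide-type nitrogen. Going by the values given here, this is again an aryl-for-aryl exchange on the amide-type nitrogen, and the one such exchange measured so far, a number 4.9 percentage points higher from compound 2 to compound 3 (within the scatter), did not move the number beyond the scatter. Among the compounds with values here, no step bearing on a pyridin-3-yl group has been measured, so this is the only guide. For compound 4 the expected step of a number 0.6 percentage points higher from compound 3 to compound 4 (within the scatter) is therefore no change beyond the scatter in this assay. Compound 4 is estimated at 8%, with a range of 0% to 20%.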

Compound 4, a percentage reported as inhibition, in the whole organism at one dose (the size of the read-out at that dose, not a potency): 30.8%
Compound 4: middle estimate off by 22.8 percentage points, on the low side; measured number above the stated range.
By their numbers in this assay, from the lowest: compounds 2 and 3 (each within the scatter of the next); then compounds 1 and 4 (each within the scatter of the next).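

In this assay, going by these compounds alone, the aryl group on the amide-type nitrogen proves not to be interchangeable: the exchange gives a number 23.4 percentage points higher from compound 3 to compound 4 (beyond the scatter) and a number 28.3 percentage points higher from compound 2 to compound 4 (beyond the scatter), whereas the only earlier aryl-for-aryl step stayed within the scatter. An aryl group at this position also no longer goes with a lower number than methyl, since pyridin-3-yl gives a number 9.8 percentage points higher from compound 1 to compound 4 (within the scatter), so compound 4 goes against the pattern set by compound 2 and compound 3. Nothing at hand gives a reason for these steps.

The compounds shown leave open whether the ring nitrogen of pyridin-3-yl is what separates compound 4 from compound 2 and compound 3, a question that plain phenyl, pyridin-2-yl and pyridin-4-yl on the same amide-type nitrogen would address. They also leave open how far the parity between methyl and pyridin-3-yl extends to other groups at this position, such as an ethyl, a longer alkyl chain or a benzyl group, and all of these readings rest on a single oral dose.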